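The compounds below may be only part of what the source reports. "The series", "measured", "known", "first", "only" and "open" are said of these compounds alone.

Three compounds share one core and differ only in the group carried on an aromatic nitrogen of a five-membered ring. Compound 1 `CN(CCNCc1cn(-c2ccc(Cl)cc2)nn1)CCNc1ccnc2cc(Cl)ccc12` carries a 4-chlorophenyl group there and in a functional assay on BXPC-3 cells (Homo sapiens) for antiproliferative activity, read by sulforhodamine B assay, with a stated time of 72 h (on this read-out higher numbers stand for weaker inhibition and lower numbers for stronger inhibition), compound 1 gives 9100 nM. Compound 2 `CN(CCNCc1cn(-c2ccc(Br)cc2)nn1)CCNc1ccnc2cc(Cl)ccc12` carries a 4-bromophenyl group and in this assay compound 2 gives 7900 nM; the step of a 1.2-fold lower number from compound 1 to compound 2 (0.06 log units; within the scatter) is within the scatter. Compound 3 `CN(CCNCc1cn(C(C)(C)C)nn1)CCNc1ccnc2cc(Cl)ccc12` carries a tert-butyl group and in this assay compound 3 gives 39000 nM, the highest number of the three, that is the weakest inhibition. The steps of a 4.3-fold higher number from compound 1 to compound 3 (0.63 log units; beyond the scatter) and a 4.9-fold higher number from compound 2 to compound 3 (0.69 log units; beyond the scatter) both lie beyond the scatter and point the same way: swapping an aromatic group for tert-butyl at this position weakens inhibition modestly.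

Compound 4 `CN(CCNCc1cn(-c2nc3ccccc3[nH]2)nn1)CCNc1ccnc2cc(Cl)ccc12` reverses that direction. Its change from compound 3 is 1H-benzimidazol-2-yl in place of tert-butyl on an aromatic nitrogen. Since the two measured steps concern an aromatic group leaving this position, and here an aromatic group enters it, the expectation is that the number in this assay falls again by a modest amount, though a benzimidazole is not a halogenated phenyl, so the size is uncertain. The estimated step is a 3.9-fold lower number from compound 3 to compound 4 (0.59 log units; beyond the scatter). Compound 4 is therefore expected to give about 10000 nM, within a range from 3000 nM to 35000 nM.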

Compound 4, half-maximal inhibitory concentration: 16000 nM
Compound 4: middle estimate off by 1.6-fold (0.20 log units), on the low side; measured number inside the range.
By their numbers in this assay, from the lowest: compounds 2, 1 and 4 (each within the scatter of the next, the first and the last beyond it); then compound 3.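

In this assay, the advantage over tert-butyl at this position is not confined to halogenated phenyl groups: a 1H-benzimidazol-2-yl group, with two aromatic rings, also gives a better result (a 2.4-fold lower number from compound 3 to compound 4 (0.39 log units; beyond the scatter)). The larger group brings no gain over the single-ring groups, however: replacing 4-bromophenyl with it gives a modest loss (a 2.0-fold higher number from compound 2 to compound 4 (0.31 log units; beyond the scatter)), while replacing 4-chlorophenyl gives a change that stays within the scatter (a 1.8-fold higher number from compound 1 to compound 4 (0.25 log units; within the scatter)), so adding a second ring and a hydrogen-bond donor does not improve on the halogenated phenyl groups in this small set. Nothing available explains why these groups fall in this order, and the numbers alone describe the trend without giving its cause.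

The compounds shown leave open whether the halogen matters at all, a question that a plain phenyl group would address, and whether a ring is needed, which a straight butyl chain could test against tert-butyl. They also leave open how a charged group such as a carboxylic acid or an amine on the phenyl ring would fare here.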